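Chloro to dimethylamino on the aryl ring of compound 2

The source may hold more compounds than are shown below. What is called first, only, known or untested is meant among the compounds shown, and "the series" means these compounds.

Measured so far in this series:
compound 1 `COc1ccc(C2CC(c3ccccc3)=NN2C2=NC(=O)/C(=C3\C(=O)Nc4ccccc43)S2)cc1`: 2010 nM
compound 2 `O=C1N=C(N2N=C(c3ccccc3)CC2c2ccc(Cl)cc2)S/C1=C1/C(=O)Nc2ccccc21`: 270 nM

Within the data shown here, in a functional assay on cells (Cancer cell lines, Homo sapiens) for cytotoxicity, read by sulforhodamine B assay, with a stated time of 48 h (on this read-out higher numbers stand for weaker inhibition of growth and lower numbers for stronger inhibition of growth), compound 2 holds the lowest of the two numbers recorded so far, and the only other measured compound, compound 1, sits well apart from it. Among the measured compounds shown here, the single measured step in the set, a 7.4-fold lower number from compound 1 to compound 2 (0.87 log units; beyond the scatter), comes from chloro in place of methoxy on an aromatic carbon and lies beyond the scatter, so the group at this position clearly matters for the read-out.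

Compound 3 `CN(C)c1ccc(C2CC(c3ccccc3)=NN2C2=NC(=O)/C(=C3\C(=O)Nc4ccccc43)S2)cc1` carries the change (dimethylamino in place of chloro on an aromatic carbon). For the measured compounds named here, no measured step touches dimethylamino at this position; the step from compound 1 to compound 2 is the only guide, and it shows that swapping the group here can shift the number by a modest but real amount. The direction for dimethylamino is therefore uncertain, and a move of roughly the same size as a 7.4-fold lower number from compound 1 to compound 2 (0.87 log units; beyond the scatter) in either direction is plausible. On balance the number for compound 3 is expected to rise, by about a 3.0-fold higher number from compound 2 to compound 3 (0.47 log units; beyond the scatter). The estimate for compound 3 in this assay is 800 nM, with a range from 200 nM to 3000 nM.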

Compound 3, concentration for 50% growth inhibition: 6370 nM
For compound 3 the middle estimate is 8.0-fold (0.90 log units) below the measured one; measured number above the stated range.
By their numbers in this assay, from the lowest: compound 2; then compound 1; then compound 3.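

In this assay, among these compounds, going from 4-chlorophenyl to 4-(dimethylamino)phenyl gives a 24-fold higher number from compound 2 to compound 3 (1.37 log units; beyond the scatter), the widest step so far at this position and a much wider spread than the first pair of compounds showed. Methoxy and dimethylamino also separate, with a 3.2-fold higher number from compound 1 to compound 3 (0.50 log units; beyond the scatter), so the three groups fall in a clear order, chloro lowest, then methoxy, then dimethylamino, with every gap beyond the scatter and both groups attached through oxygen or nitrogen standing above chloro. Nothing available explains this order.

As far as these compounds go, whether the low number belongs to chloro alone or extends to other groups on the same ring carbon, such as fluoro, bromo or methyl, stays open, as does the result for the unsubstituted phenyl ring. A primary amine at this place would show whether the rise seen with dimethylamino stays with the nitrogen or depends on its two methyl groups.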